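A few compounds are considered here, and "the series" means these few. Any claim that something is new, unique, unknown or untested is made for them only; others in the source may bear on it.

Compound 1 `CCCc1ccc(C#CC#Cc2cn([C@H]3C[C@H](O)[C@@H](CO)O3)c(=O)[nH]c2=O)cc1` gives 52000 nM in an ADME assay on HEL cells (Homo sapiens), read by cell counting, with a stated time of 3 days; on this read-out higher numbers stand for lower toxicity in this test and lower numbers for higher toxicity in this test. Compound 2 `O=c1[nH]c(=O)n([C@H]2C[C@H](O)[C@@H](CO)O2)cc1C#CC#Cc1ccccn1` gives 1500 nM in this assay. Compound 3 `Nc1ccc(C#CC#Cc2cn([C@H]3C[C@H](O)[C@@H](CO)O3)c(=O)[nH]c2=O)cc1` gives > 100000 nM in this assay, which is a limit of the assay and not a number.

Within the data shown here, compound 3 is the one value that sits at the limit of > 100000 nM in this assay, at which 1 of the 3 values shown sits, so its standing among the three is bounded on one side only. Compound 4 `O=c1[nH]c(=O)n([C@H]2C[C@H](O)[C@@H](CO)O2)cc1C#CC#Cc1ccc([N+](=O)[O-])cc1` differs from compound 3 by nitro in place of amino on an aromatic carbon. Among the measured compounds shown here, no measured step involves a nitro group. The closest comparison is an at least 1.9-fold higher number from compound 1 to compound 3 (0.28 log units; that floor lies within the scatter), a change on the same aromatic carbon that stays within the scatter, whereas a 35-fold lower number from compound 1 to compound 2 (1.54 log units; beyond the scatter) and an at least 66-fold higher number from compound 2 to compound 3 (1.82 log units; beyond the scatter) exchange the whole ring and are large. A step no larger than the scatter is therefore expected, with a fair chance that the assay again reports only a limit. Compound 4 is estimated at 80000 nM, within 20000 nM to 200000 nM, an expected step of an at least 1.2-fold lower number from compound 3 to compound 4 (0.09 log units; that floor lies within the scatter).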

Compound 4, half-maximal cytotoxic concentration: 89000 nM
For compound 4 the middle estimate is 1.1-fold (0.05 log units) below the measured one; measured number inside the range.
By their numbers in this assay, from the lowest: compound 2; then compounds 1 and 4 (each within the scatter of the next). At a limit, above all of these: compound 3.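

In this assay, nitro in place of amino on an aromatic carbon para to a large group gives an at least 1.1-fold lower number from compound 3 to compound 4 (0.05 log units; that floor lies within the scatter), and nitro in place of propyl gives a 1.7-fold higher number from compound 1 to compound 4 (0.23 log units; within the scatter); neither step leaves the scatter. With 4-nitrophenyl in place of pyridin-2-yl, a 59-fold higher number from compound 2 to compound 4 (1.77 log units; beyond the scatter) shows a third para-substituted phenyl far from compound 2, and no compound shown goes against this. Compound 3 remains a limit of the assay, so its step gives only a floor: the limit of > 100000 nM in this assay, at which 1 of the 4 values shown sits.

On these data alone, whether a carboxylic acid or a longer chain on this carbon stays in the same range remains open. So does whether pyridin-3-yl would stand with compound 2 or with the phenyl compounds.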